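Replacing fluoro with an amide on the bicyclic ether core

A few compounds are considered here, and "the series" means these few. Any claim that something is new, unique, unknown or untested is made for them only; others in the source may bear on it.

Measured so far:
Compound 1 `O=C(c1ccc2c(c1)CC(c1nc3ccc(-c4cn[nH]c4)cc3c(=O)[nH]1)CO2)C1CC1`: 3.63 h
Compound 2 `Cc1ccc2c(c1)CC(c1nc3ccc(-c4cn[nH]c4)cc3c(=O)[nH]1)CO2`: 0.517 h
Compound 3 `O=c1[nH]c(C2COc3ccc(F)cc3C2)nc2ccc(-c3cn[nH]c3)cc12`: 2.38 h

Of the compounds shown here, three sharing one core have been tested in an in vitro ADME assay on microsomes from liver (Homo sapiens) for metabolic stability (a higher number here means that the compound lasts longer, a lower number that the compound disappears faster), and they differ only in the group on an aromatic carbon of the six-membered ring of carbon only. Compound 3, which carries fluoro there, stands second of the three; one of its steps is a 1.5-fold lower number from compound 1 to compound 3 (0.18 log units; within the scatter), within the scatter, while the other is a 4.6-fold higher number from compound 2 to compound 3 (0.66 log units; beyond the scatter), beyond it.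

Compound 4 `COCCNC(=O)c1ccc2c(c1)CC(c1nc3ccc(-c4cn[nH]c4)cc3c(=O)[nH]1)CO2` is the next compound of interest. Its change from compound 3 is (2-methoxyethyl)carbamoyl in place of fluoro on an aromatic carbon.

Going by the values given here, no measured step involves a carbamoyl group, so the bearing of the known steps is indirect. The closest comparison is compound 1, whose cyclopropylcarbonyl also brings a carbonyl to this position, and the step of a 1.5-fold lower number from compound 1 to compound 3 (0.18 log units; within the scatter) shows that fluoro and that carbonyl group give numbers within the scatter of each other. Only the methyl of compound 2 gave a clearly lower value, in the step of a 4.6-fold higher number from compound 2 to compound 3 (0.66 log units; beyond the scatter). On this basis, compound 4 is expected to show a step of a 1.3-fold higher number from compound 3 to compound 4 (0.10 log units; within the scatter) in this assay, that is no change beyond the scatter, with a leaning toward a somewhat longer half-life. The estimate for compound 4 is therefore 3 h, expected to fall between 1.2 h and 7.5 h.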

Compound 4, half-life: 0.7 h
Compound 4: the middle estimate sits 4.3-fold (0.63 log units) above what was measured; the whole stated range lies above it.
By their numbers in this assay, from the lowest: compounds 2 and 4 (each within the scatter of the next); then compounds 3 and 1 (each within the scatter of the next).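

In this assay, going by these compounds alone, the earlier compounds left open whether a carbonyl on this aromatic carbon was enough to give a long half-life, and compound 4 shows that it is not: in a 5.2-fold lower number from compound 1 to compound 4 (0.71 log units; beyond the scatter), both compounds keep the carbonyl and only the group on it changes, so what is attached to the carbonyl matters. The step of a 3.4-fold lower number from compound 3 to compound 4 (0.53 log units; beyond the scatter) shows that this (2-methoxyethyl)carbamoyl group does not match fluoro here, while a 1.4-fold higher number from compound 2 to compound 4 (0.13 log units; within the scatter) places compound 4 with the methyl compound, so the compounds now form two groups and a carbonyl-bearing compound stands in each. No measured evidence here explains this difference between the two carbonyl groups.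

The compounds shown cannot separate the contribution of the amide link from that of the 2-methoxyethyl chain. A plain carbamoyl or a methylcarbamoyl group at this place would help to divide the two, and a chain ending in an amine or a carboxylic acid would show how far the outcome depends on the end of the chain.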